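This account rests on a few compounds, and the source may have more. Where it says the series, first, only, none or still open, it means among the compounds named here.

In an ADME assay on microsomes from liver (Rattus norvegicus) for metabolic stability, read by LC-MS, using NADPH, with a stated time of 10 min, tested at 0.1 uM (a higher number here means faster removal of the compound, a lower number slower removal), compound 2 `Cc1cccc(N2C(=O)CSC2c2cccc(C(=O)NCCCCc3ccccc3)c2)c1` gives 3140 mL.min-1.g-1, the highest of the three numbers. The gaps down to compound 1 `COc1ccc(F)cc1N1C(=O)CSC1c1cccc(C(=O)NCCCCn2cccn2)c1` at 1470 mL.min-1.g-1 and compound 3 `Cc1ccnc(N2C(=O)CSC2c2cccc(C(=O)NCCCCn3cccn3)c2)c1` at 1020 mL.min-1.g-1 both lie beyond the scatter. Compound 4 `O=C(NCCCCc1ccccc1)c1cccc(C2SCC(=O)N2c2ccccc2F)c1` carries 2-fluorophenyl in place of 3-methylphenyl on an amide-type nitrogen in a ring. Going by the values given here, only one measured step changes the group at this place: a 1.4-fold lower number from compound 1 to compound 3 (0.16 log units; within the scatter), which lies within the scatter. Both of those compounds also differ from compound 2 elsewhere, so the guide is limited. No change beyond the scatter is expected in this assay. The expected step is a 1.2-fold lower number from compound 2 to compound 4 (0.07 log units; within the scatter). For compound 4 the estimate is 2700 mL.min-1.g-1, with an expected range of 1300 mL.min-1.g-1 to 5400 mL.min-1.g-1.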

Compound 4, intrinsic clearance in microsomes: 2950 mL.min-1.g-1
Compound 4: the middle estimate sits 1.1-fold (0.04 log units) below what was measured, within the range that was stated.
By their numbers in this assay, from the lowest: compounds 3, 1, 4 and 2 (each within the scatter of the next, the first and the last beyond it).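

With the rest of compound 2 held constant, 2-fluorophenyl in place of 3-methylphenyl on the amide-type nitrogen gives, in this assay, the first clean read of this position on this side chain (a 1.1-fold lower number from compound 2 to compound 4 (0.03 log units; within the scatter)). Together with the earlier step (a 1.4-fold lower number from compound 1 to compound 3 (0.16 log units; within the scatter)), that makes two steps at this place, on two different side chains, and both lie within the scatter. No measurement shown accounts for this result.
Only aromatic rings are shown at this place, so it remains open whether a dimethylamino group or a carboxylic acid on the ring, or a cyclohexyl ring in its stead, would give a step beyond the scatter.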